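Swapping a long chain for a short ester on the amine

The source may hold more compounds than are shown below. What is called first, only, known or untested is meant among the compounds shown, and "the series" means these compounds.

Of the compounds shown here, three built on a shared core have been measured in an assay on VSM-A10 cells for antagonist activity at Endothelin-1 receptor (Rattus norvegicus); a higher number here means a weaker inhibitor, a lower number a stronger inhibitor. Compound 1 `Cc1onc(NS(=O)(=O)c2cccc3c(N(C)C)cccc23)c1C` gives 60 nM, compound 2 `Cc1noc(NS(=O)(=O)c2cccc3c(NCCCCCc4ccccc4)cccc23)c1C` gives 3050 nM, and compound 3 `CCOC(=O)c1c(C)noc1NS(=O)(=O)c1cccc2c(N(C)C)cccc12` gives 31000 nM. Compound 2 therefore holds the second highest of the three numbers, well clear of both neighbours. Compound 4 `CCOC(=O)C(C)Nc1cccc2c(S(=O)(=O)Nc3onc(C)c3C)cccc12` is not yet measured; it differs from compound 2 in one place: 1-(ethoxycarbonyl)ethyl in place of 5-phenylpentyl on a nitrogen on an aromatic ring. Going by the values given here, with no measured pair showing a comparable change, the expectation leans on compound 1, whose smaller group on that nitrogen goes with 60 nM, so a drop beyond the scatter is expected, a 5.1-fold lower number from compound 2 to compound 4 (0.71 log units; beyond the scatter). Compound 4 is estimated to give 600 nM, within 120 nM to 3000 nM.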

Compound 4, half-maximal inhibitory concentration: 400 nM
For compound 4 the middle estimate is 1.5-fold (0.18 log units) above the measured one, and the stated range covers the measured number.
By their numbers in this assay, from the lowest: compound 1; then compound 4; then compound 2; then compound 3.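

In this assay, going by these compounds alone, this is the first measured change on this nitrogen on an aromatic ring, and 1-(ethoxycarbonyl)ethyl in place of 5-phenylpentyl gives a 7.6-fold lower number from compound 2 to compound 4 (0.88 log units; beyond the scatter), so this one group alone moves the number beyond the scatter. The entering group has fewer heavy atoms, no ring and two hydrogen-bond acceptors, but nothing measured shows which of these differences matters or why the number falls.

A plain pentyl chain would separate the loss of the phenyl ring from the loss of chain length. A carboxylic acid in place of the ethyl ester would test whether the ester itself matters.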